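Swapping a cyclohexyl arm for a cyclobutyl amide on the shared core

The compounds below may be only part of what the source reports. "The series", "measured", "known", "first", "only" and "open" are said of these compounds alone.

Measured so far:
- compound 1 `CO[C@H]1CC[C@H](CNc2cc(NCc3cnccc3C(F)(F)F)ncc2C#N)CC1`: 330 nM
- compound 2 `N#Cc1cnc(NCc2cnccc2C(F)(F)F)cc1N[C@H]1CC[C@@H](c2nc[nH]n2)CC1`: 34 nM
- compound 3 `CC1(C)[C@H](O)C[C@H]1Nc1nc(NCc2cnccc2C(F)(F)F)ncc1C#N`: 130 nM

In an assay on isolated protein for inhibition of protein kinase C theta type (Homo sapiens), read by TR-FRET, with a stated time of 2 h (on this read-out lower numbers stand for stronger inhibition and higher numbers for weaker inhibition), compound 1 gives 330 nM, the highest of the three numbers. Compound 3 sits nearer to it, compound 2 furthest away, and both gaps lie beyond the scatter, so compound 1 is the weakest inhibitor of the measured set. Compound 4 `CC1(C)[C@H](Nc2cc(NCc3cnccc3C(F)(F)F)ncc2C#N)C[C@H]1C(N)=O` differs from compound 1 in one place: 3-carbamoyl-2,2-dimethylcyclobutyl in place of (4-methoxycyclohexyl)methyl on a nitrogen on an aromatic ring. Among the measured compounds shown here, no step between measured compounds matches this change directly, yet compound 2 and compound 3, which carry a ring joined straight to the nitrogen, show lower numbers than compound 1. The step of a 3.0-fold lower number from compound 1 to compound 4 (0.48 log units; beyond the scatter) is therefore expected to run downward, beyond the scatter. Compound 4 is estimated at 110 nM, within 35 nM to 330 nM.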

Compound 4, half-maximal inhibitory concentration: 140 nM
Compound 4: middle estimate off by 1.3-fold (0.10 log units), on the low side; low and high end bracket the measured number.
By their numbers in this assay, from the lowest: compound 2; then compounds 3 and 4 (each within the scatter of the next); then compound 1.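

Among the compounds shown here, this is the first direct reading at this position: in this assay, 3-carbamoyl-2,2-dimethylcyclobutyl in place of (4-methoxycyclohexyl)methyl on the nitrogen gives a 2.4-fold lower number from compound 1 to compound 4 (0.37 log units; beyond the scatter), a modest gain. The swap changes the ring size, drops the carbon link to the nitrogen and adds a hydrogen-bond donor all at once, so the step cannot be assigned to any one of these. No measurement here explains the gain.

Still open, on these data alone, is whether the carbamoyl group matters, since the cyclobutyl ring has not been seen carrying a carboxylic acid or an amine in its place.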